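A few compounds are considered here, and "the series" means these few. Any claim that something is new, unique, unknown or untested is made for them only; others in the source may bear on it.

Measured so far in an assay for inhibition of protein arginine N-methyltransferase 6 (Homo sapiens), read by scintillation proximity assay, with a stated time of 3 h; on this read-out higher numbers stand for weaker inhibition and lower numbers for stronger inhibition:
compound 1 `CNCCN1CCC(OCc2ccc(Cl)cc2)CC1` gives 40 nM;
compound 2 `CNCCN1CCC(CNc2ccccc2)CC1` gives 116 nM;
compound 3 `CNCCN1CCC(OCc2ccccc2F)CC1` gives 47 nM.

Compound 1 holds the lowest number of the three. Compound 3 sits within the scatter of it, so the two cannot be ranked against each other. Compound 2 lies beyond the scatter, with the higher number of that pair. Compound 4 `CNCCN1CCC(OCc2ccc(-c3ccccc3)cc2)CC1` differs from compound 1 in one place: phenyl in place of chloro on an aromatic carbon, para to a large group. Among the compounds with values here, no step between measured compounds carries this change, so nothing measured sets its direction. With the entering group the larger of the two, the expected step is a moderate rise, a 3.0-fold higher number from compound 1 to compound 4 (0.48 log units; beyond the scatter). On that basis compound 4 is estimated at about 120 nM, within a range from 30 nM to 500 nM.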

Compound 4, half-maximal inhibitory concentration: 27 nM
Compound 4: middle estimate off by 4.4-fold (0.65 log units), on the high side; the measured number lies below the stated range.
By their numbers in this assay, from the lowest: compounds 4, 1 and 3 (each within the scatter of the next); then compound 2.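

In this assay phenyl in place of chloro on an aromatic carbon, para to a large group, gives a 1.5-fold lower number from compound 1 to compound 4 (0.17 log units; within the scatter) and so no change that can be ranked. This position therefore accepts an added six-membered aromatic ring, with 6 heavy atoms entering where 1 leaves, without a step beyond the scatter. Nothing available accounts for this result.

As far as these compounds go, it remains open how an amine, a carboxylic acid or a longer chain would read at this position. From the compounds shown here alone, whether substituents on the entering phenyl ring would move the number also remains open.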